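A few compounds are considered here, and "the series" means these few. Any claim that something is new, unique, unknown or untested is made for them only; others in the source may bear on it.

In an assay on isolated protein for inhibition of DNA topoisomerase 1 (Homo sapiens), with a stated time of 15 min (on this read-out lower numbers stand for stronger inhibition and higher numbers for weaker inhibition), the measured compounds are:
compound 1 `COc1c(N2CC[C@@H](CN)C2)c(F)cc2c(=O)c(C(=O)O)cn(Cc3ccc(-c4ccccc4)cc3)c12` with 26000 nM;
compound 2 `COc1c(N2CC[C@@H](CN)C2)c(F)cc2c(=O)c(C(=O)O)cn(Cc3cc(-c4ccccc4)no3)c12` with 178000 nM.

Compound 2 stands highest of the two numbers in this assay; its nearest neighbour is compound 1, separated by a step beyond the scatter. Compound 3 `COc1c(N2CC[C@@H](CN)C2)c(F)cc2c(=O)c(C(=O)O)cn(Cc3ccc4ccccc4c3)c12` differs from compound 2 by naphthalen-2-yl in place of 3-phenyl-1,2-oxazol-5-yl on a saturated chain carbon bound to an aromatic nitrogen. For the measured compounds named here, the one measured step that bears on this is a 6.8-fold higher number from compound 1 to compound 2 (0.84 log units; beyond the scatter), where an all-carbon aromatic group gave way to the oxazole-containing one. Because that step ran a 6.8-fold higher number from compound 1 to compound 2 (0.84 log units; beyond the scatter), and naphthalen-2-yl restores an all-carbon aromatic group, a lower number is expected for compound 3, a 5.9-fold lower number from compound 2 to compound 3 (0.77 log units; beyond the scatter). Compound 3 is estimated at 30000 nM, within 10000 nM to 100000 nM.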

Compound 3, half-maximal inhibitory concentration: 43700 nM
For compound 3 the middle estimate is 1.5-fold (0.16 log units) below the measured one; the range from low to high includes it.
By their numbers in this assay, from the lowest: compounds 1 and 3 (each within the scatter of the next); then compound 2.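

In this assay, for the compounds shown here, naphthalen-2-yl on a saturated chain carbon bound to an aromatic nitrogen also separates from 3-phenyl-1,2-oxazol-5-yl (a 4.1-fold lower number from compound 2 to compound 3 (0.61 log units; beyond the scatter)), so 4-phenylphenyl is no longer the only all-carbon group to do so. Naphthalen-2-yl and 4-phenylphenyl cannot be told apart at this place (a 1.7-fold higher number from compound 1 to compound 3 (0.23 log units; within the scatter)). No measured evidence on these compounds bears on this result.

Going by these compounds, it remains open how a plain phenyl group or a longer chain at this place would read out. An amine or a carboxylic acid on the aromatic group also remains untested among the compounds shown.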